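Shrinking the Ring Substituent on the Shared Core

This account rests on a few compounds, and the source may have more. Where it says the series, first, only, none or still open, it means among the compounds named here.

Two measured compounds share one core and differ only in the group on a single aromatic carbon. Compound 1 `Nc1cc(C2CCCC2)nc2ccc(NC(=O)/C=C/c3ccc(C(F)(F)F)cc3)cc12` carries cyclopentyl, and in an assay on isolated protein for displacement of a labelled ligand from melanin-concentrating hormone receptor 1 (Homo sapiens) (a lower number here means a stronger inhibitor, a higher number a weaker inhibitor), compound 1 gives 0.8 nM. Compound 2 `Nc1cc(C2CCC2)nc2ccc(NC(=O)/C=C/c3ccc(C(F)(F)F)cc3)cc12` carries cyclobutyl instead, and in this assay compound 2 gives 2 nM. Compound 2 therefore has the higher of the two numbers, and the step of a 2.5-fold higher number from compound 1 to compound 2 (0.40 log units; beyond the scatter) shows that the smaller ring came with a modest loss. Compound 3 `Cc1cc(N)c2cc(NC(=O)/C=C/c3ccc(C(F)(F)F)cc3)ccc2n1` continues in the same direction: methyl in place of cyclobutyl on an aromatic carbon. Among the measured compounds shown here, the only step that bears on this is a 2.5-fold higher number from compound 1 to compound 2 (0.40 log units; beyond the scatter), and since the new change goes further, from a ring to methyl, a loss of similar or somewhat greater size is expected, though without certainty that the trend continues evenly. The expected step is a 3.0-fold higher number from compound 2 to compound 3 (0.48 log units; beyond the scatter). Compound 3 is estimated at 6 nM, within a range from 2 nM to 20 nM.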

Compound 3, half-maximal inhibitory concentration: 8 nM
Estimate against measurement, compound 3: 1.3-fold (0.12 log units) below; the range from low to high includes it.
By their numbers in this assay, from the lowest: compound 1; then compound 2; then compound 3.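

Going from a ring to no ring at all, methyl on this aromatic carbon gives a 4.0-fold higher number from compound 2 to compound 3 (0.60 log units; beyond the scatter), so the loss seen on shrinking the ring continues once the ring is gone. Across all three compounds, the number rises in step with the shrinking group, with none going against this order, and the full change amounts to a 10-fold higher number from compound 1 to compound 3 (1.00 log units; beyond the scatter); even so, compound 3 keeps a measurable nanomolar-range value of 8 nM in this assay. Nothing available explains why the smaller groups give higher numbers.

On these data alone, whether a group larger than cyclopentyl, such as cyclohexyl, would lower the number further remains open. Also open, as far as these compounds go, is how a group containing nitrogen or oxygen, such as an amine or methoxy, would behave on this carbon.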